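This account rests on a few compounds, and the source may have more. Where it says the series, first, only, none or still open, it means among the compounds named here.

Compound 1 `O=C1C=C(Nc2ccc(Br)cc2)C(=O)c2c1nc1n2[C@H]2OC[C@@H](O)[C@H]2OC1`: 3830 nM
Compound 2 `COc1cccc(NC2=CC(=O)c3nc4n(c3C2=O)[C@H]2OC[C@@H](O)[C@H]2OC4)c1`: 4280 nM

Among the compounds with values here, in a functional assay on HeLa cells (Homo sapiens) for inhibition, read by sulforhodamine B assay (on this read-out lower numbers stand for stronger inhibition and higher numbers for weaker inhibition), compound 2 at 4280 nM stands level with compound 1, the only other measured compound, and the two values cannot be told apart.

Compound 3 `O=C1C=C(N2CCCC2)C(=O)c2c1nc1n2[C@H]2OC[C@@H](O)[C@H]2OC1` keeps the shared core but exchanges one group: pyrrolidin-1-yl in place of (3-methoxyphenyl)amino on a double-bonded ring carbon. Put simply, pyrrolidin-1-yl sits in place of (3-methoxyphenyl)amino on a double-bonded ring carbon.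

Within the data shown here, only one measured step bears on this: a 1.1-fold higher number from compound 1 to compound 2 (0.05 log units; within the scatter), where 3-methoxyphenyl replaces 4-bromophenyl on an amine nitrogen. Among the measured compounds shown here, it offers only weak guidance, as no measured compound carries pyrrolidin-1-yl.

In this assay, the expected result is therefore no step beyond the scatter, in either direction, with considerable uncertainty. The estimated step is a 1.2-fold higher number from compound 2 to compound 3 (0.07 log units; within the scatter). For compound 3 the estimate is 5000 nM, with an expected range of 1500 nM to 16000 nM.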

Compound 3, half-maximal inhibitory concentration: > 16000 nM
Compound 3: no number, only a limit (the forecaster's own chance of this, stated with the estimate: 10%); at least 3.2-fold (0.50 log units) between middle value and limit.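

Compound 3 gives only a limit in this assay, not a number: the limit of > 16000 nM in this assay, at which 1 of the 3 values shown sits.

Even so, the steps can be read. Putting pyrrolidin-1-yl in place of (3-methoxyphenyl)amino gives an at least 3.7-fold higher number from compound 2 to compound 3 (0.57 log units; beyond the scatter), and putting it in place of (4-bromophenyl)amino gives an at least 4.1-fold higher number from compound 1 to compound 3 (0.62 log units; beyond the scatter). Inhibition on this double-bonded ring carbon therefore weakens beyond the scatter when the whole arylamino group is exchanged, something the earlier swap of one substituted phenyl for another, a 1.1-fold higher number from compound 1 to compound 2 (0.05 log units; within the scatter), did not show.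

This exchange removes the aromatic ring and the hydrogen-bond donor together, so the compounds shown cannot tell which of the two matters. From the compounds shown here alone, how a cyclohexylamino group, which has an amine hydrogen but no aromatic ring, or a benzylamino group would fare at this carbon stays open.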